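Swapping the fluorophenyl arm: what cytotoxicity to expect

The source may hold more compounds than are shown below. What is called first, only, known or untested is meant among the compounds shown, and "the series" means these compounds.

Measured compounds:
compound 1, `CC1(C)OC(=O)C2(C(=O)O1)[C@@H](c1ccco1)CC(=O)C[C@H]2c1ccc(F)cc1` — > 111000 nM
compound 2, `COc1cc([C@@H]2CC(=O)C[C@H](c3ccco3)C23C(=O)OC(C)(C)OC3=O)ccc1O` — > 111000 nM

Both values come from an ADME assay on MT2 cells (Homo sapiens) for cytotoxicity; on this read-out higher numbers stand for lower toxicity in this test and lower numbers for higher toxicity in this test. For compound 1 the reading of > 111000 nM is a limit of the assay and not a number. For compound 2 the reading of > 111000 nM is likewise only a limit. The step that the two limits leave unreadable from compound 1 to compound 2 is therefore not readable, since (the limit of > 111000 nM in this assay, at which 2 of the 2 values shown sit).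

Compound 3, `COc1ccc([C@@H]2CC(=O)C[C@H](c3ccco3)C23C(=O)OC(C)(C)OC3=O)c(C)c1`, has not been measured. Against compound 1 it carries 4-methoxy-2-methylphenyl in place of 4-fluorophenyl on a saturated ring carbon. For the measured compounds named here, the only measured step, from compound 1 to compound 2, also exchanges the aryl group on this saturated ring carbon, and its size could not be read. Going by the values given here, nothing among the measured numbers suggests a readable change for compound 3. Compound 3 is thus expected to give 111000 nM in this assay, in a range from 50000 nM to 250000 nM, most likely again only as a limit. The expected step of a number no higher from compound 1 to compound 3 (the limit leaves the size open) is none beyond the scatter.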

Compound 3, half-maximal cytotoxic concentration: > 111000 nM
Compound 3 ended at the assay's limit; the forecaster's own chance of this, stated with the estimate: 80%; the middle value sits exactly at the limit.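

In this assay no step can be read from compound 1 or compound 2 to compound 3, as each reading is a limit and not a number: the limit of > 111000 nM in this assay, at which 3 of the 3 values shown sit.

The compounds shown leave open whether these three aryl groups differ at all in cytotoxicity beyond that limit.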